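Lengthening the chain of compound 1

The source may report more compounds than this note shows. Statements on the series, on what has been measured and on what is new or still open speak of the compounds shown alone.

Among the compounds with values here, in a functional assay on M109 cells (Mus musculus) for cytotoxicity (on this read-out higher numbers stand for weaker inhibition and lower numbers for stronger inhibition), compound 1 (`CCCCCCCC1=CC(=O)C=C(OC)C1=O`) gives 10 ug/mL as the only number available, so it cannot be ranked against anything. Compound 2 (`CCC1=CC(=O)C=C(OC)C1=O`) adds no comparison, with "not determined" (no result reported) as its entry. Compound 3 (`CCCCCCCCCCC1=CC(=O)C=C(OC)C1=O`) departs from compound 1 in a single change (propyl in place of hydrogen on a saturated chain carbon, seven bonds along the chain from a double-bonded ring carbon), which lengthens the chain. Within the data shown here, no measured step shows what such a change does, so in this assay no shift beyond the usual scatter is expected, with only a slight lean towards stronger inhibition. The estimated change is a 1.3-fold lower number from compound 1 to compound 3 (0.10 log units; within the scatter) and thus small. Compound 3 is expected at 8 ug/mL (estimated range 3 ug/mL to 25 ug/mL).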

Compound 3, half-maximal inhibitory concentration: 10 ug/mL
For compound 3 the middle estimate is 1.3-fold (0.10 log units) below the measured one; low and high end bracket the measured number.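

In this assay, within the data shown here, the step of no change at the digits printed from compound 1 to compound 3 (within the scatter) is the first measured comparison for this position. It shows that propyl in place of hydrogen on this saturated chain carbon leaves the read-out within the scatter, so this lengthening of the chain does not separate the two compounds. The compounds shown leave open whether a longer chain in place of the propyl would also leave the read-out unmoved. They also leave open what an amine or a carboxylic acid would do there. Nothing available bears on the reason for this result.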